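A few compounds are considered here, and "the series" means these few. Any claim that something is new, unique, unknown or untested is made for them only; others in the source may bear on it.

Notes on the series. Three ureas share one core; they differ only in the group carried on an aromatic carbon. Compound 1 `C[C@H](NC(=O)Nc1ccccc1C(C)(C)C)c1ccccc1` carries a tert-butyl group, compound 2 `C[C@H](NC(=O)Nc1ccccc1F)c1ccccc1` a fluoro group and compound 3 `C[C@H](NC(=O)Nc1ccccc1I)c1ccccc1` an iodo group. In an ADME assay on the whole organism with Oryza sativa as the target, tested at 0.1 uM (a higher number here means a weaker effect of the compound at the concentration tested, a lower number a stronger effect), compound 1 gives 101%, compound 2 gives 98% and compound 3 gives 99%. Compound 2 has the lowest of the three numbers, yet the step of a number 3 percentage points lower from compound 1 to compound 2 (within the scatter) and the step of a number 1 percentage points higher from compound 2 to compound 3 (within the scatter) are both within the scatter, so no order among the three compounds can be read from these numbers; all three sit close to full activity, which here means a weak effect at the tested concentration.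

Compound 4 `C[C@H](NC(=O)Nc1ccc(F)cc1F)c1ccccc1` is not yet measured. Its change from compound 2: fluoro in place of hydrogen on an aromatic carbon. Among the measured compounds shown here, the steps that bear on it are the exchanges of the group on an aromatic carbon of the same core: a number 3 percentage points lower from compound 1 to compound 2 (within the scatter), a number 2 percentage points lower from compound 1 to compound 3 (within the scatter) and a number 1 percentage points higher from compound 2 to compound 3 (within the scatter). None of them moved the number beyond the scatter, whether the group exchanged was small or large. A second fluoro group is therefore expected to give no step beyond the scatter, a number 1 percentage points higher from compound 2 to compound 4 (within the scatter), in this assay. Compound 4 is estimated at 99%, with a range from 90% to 106%.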

Compound 4, a percentage reported as activity, at one concentration (the size of the read-out at that concentration, not a potency): 101%
Compound 4: middle estimate off by 2 percentage points, on the low side; low and high end bracket the measured number.
By their numbers in this assay, from the lowest: compounds 2, 3, 1 and 4 (each within the scatter of the next).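

Placing a fluoro group in place of hydrogen on the aromatic carbon meta to a fluoro group and para to a large group gives a number 3 percentage points higher from compound 2 to compound 4 (within the scatter) in this assay. This is the first change shown at this carbon, which carries hydrogen in compounds 1, 2 and 3, and it indicates that, for the fluoro group at least, substitution here does not shift the read-out beyond the scatter, leaving compound 4 with a weak effect at the concentration tested, like the other three compounds. No measurement of any property of these compounds is available to account for this result.

From the compounds shown here alone, whether a different group on this carbon, such as an amine, a carboxylic acid or a longer chain, would give a step beyond the scatter remains open. Also open is whether any change on the shared core can give a clearly stronger effect in this assay, as all four compounds shown lie within the scatter of one another and offer no reference for one.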